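The source may hold more compounds than are shown below. What is called first, only, known or untested is meant among the compounds shown, and "the series" means these compounds.

Measured in an ADME assay on HEK-293T cells (Homo sapiens) for inhibition, read by MTT assay, with a stated time of 48 h; on this read-out higher numbers stand for weaker inhibition and lower numbers for stronger inhibition:

Compound 1, `COc1ccc(-c2nc3cc(/C=C4\SC(=O)NC4=O)ccc3[nH]2)cc1OC`: 21700 nM
Compound 2, `COc1cc(OC)c(-c2nc3cc(/C=C4\SC(=O)NC4=O)ccc3[nH]2)cc1OC`: 15300 nM
Compound 3, `COc1cc(CN2C(=O)S/C(=C\c3ccc4[nH]c(-c5cc(OC)c(OC)c(OC)c5)nc4c3)C2=O)cc(OC)c1OC`: 16600 nM

Compound 2 and compound 1 differ in one place only: hydrogen in place of methoxy on an aromatic carbon. That change gave a 1.4-fold higher number from compound 2 to compound 1 (0.15 log units; within the scatter), so the two numbers cannot be told apart. Compound 3 differs from compound 2 in more than one place, and the difference between the two cores is not broken down here; their values in this assay lie close together.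

Compound 4, `COc1ccc(-c2nc3cc(/C=C4\SC(=O)N(Cc5cc(OC)c(OC)c(OC)c5)C4=O)ccc3[nH]2)cc1OC`, is not yet measured. It differs from compound 3 by hydrogen in place of methoxy on an aromatic carbon. This is the same kind of change as that from compound 2 to compound 1, but not the same: there the position was ortho to a large group, meta to a methoxy group and para to a methoxy group, whereas here it is ortho to a methoxy group, meta to a large group and meta to a methoxy group. Among the measured compounds shown here, the expected step from compound 3 to compound 4 in this assay is a 1.2-fold higher number from compound 3 to compound 4 (0.08 log units; within the scatter), resting on the single earlier step of a 1.4-fold higher number from compound 2 to compound 1 (0.15 log units; within the scatter), which stayed within the scatter. Compound 4 is therefore estimated at 20000 nM, with a likely range from 9000 nM to 45000 nM.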

Compound 4, half-maximal inhibitory concentration: 6760 nM
Estimate against measurement, compound 4: 3.0-fold (0.47 log units) above; measured number below the stated range.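

In this assay, replacing methoxy with hydrogen on the aromatic ring gave a 2.5-fold lower number from compound 3 to compound 4 (0.39 log units; beyond the scatter), a modest but real shift toward stronger inhibition. The same kind of change therefore cannot simply be carried from one core to the other in this series, since its result differed between the two pairs: the same change on two cores in this assay, a 1.4-fold higher number (0.15 log units; within the scatter) from compound 2 to compound 1 and a 2.5-fold lower number (0.39 log units; beyond the scatter) from compound 3 to compound 4, 3.5-fold (0.54 log units) apart, beyond the scatter of two such steps This does not show why the two results differ, since the pairs differ both in the rest of the core and in where the methoxy is lost, and two pairs cannot separate those two things, nor do they show what a third core would do.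

The compounds shown carry only methoxy or hydrogen at the position that changes, so the result of placing a hydroxyl group, a chlorine atom or an amine there remains open. Going by these compounds, it also remains open whether the 3,4,5-trimethoxyphenyl to 3,4-dimethoxyphenyl change would give the same step on any other core.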